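Swapping a Furan for a Chlorophenyl on the Acrylamide

The compounds below may be only part of what the source reports. "The series", "measured", "known", "first", "only" and "open" are said of these compounds alone.

The starting point is compound 1, `N#C/C(=C\c1ccco1)C(=O)NCc1ccc(Cl)c(Cl)c1`. In a functional assay on DU-145 cells (Homo sapiens) for inhibition, read by MTT assay, with a stated time of 72 h (on this read-out lower numbers stand for stronger inhibition of growth and higher numbers for weaker inhibition of growth), compound 1 gives 24000 nM, which is the higher of the two numbers measured here. Going by the values given here, the only other measured compound is compound 2, `COc1ccc(CNC(=O)/C(C#N)=C/c2ccc(Cl)cc2)cc1`, and in this assay compound 2 gives 7000 nM; the gap between the two lies beyond the usual scatter, but compound 2 differs from compound 1 in more than one place, so the two values only show that compound 2 is the more growth-inhibiting of the pair.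

The next compound is compound 3, `N#C/C(=C\c1ccc(Cl)cc1)C(=O)NCc1ccc(Cl)c(Cl)c1`. Compared with compound 1, the change is 4-chlorophenyl in place of furan-2-yl on a double-bonded chain carbon bound to a double-bonded chain carbon. Because compound 2, which also carries 4-chlorophenyl, gives 7000 nM, the number for compound 3 is expected to move downward rather than upward. The expected step from a 2.7-fold lower number from compound 1 to compound 3 (0.43 log units; beyond the scatter) is modest but beyond the scatter. Compound 3 is therefore estimated at 9000 nM, within a range from 3000 nM to 27000 nM.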

Compound 3, concentration for 50% growth inhibition: 30000 nM
Compound 3: middle estimate off by 3.3-fold (0.52 log units), on the low side, outside the stated range (above it).
By their numbers in this assay, from the lowest: compound 2; then compounds 1 and 3 (each within the scatter of the next).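

In this assay, exchanging furan-2-yl for 4-chlorophenyl on a double-bonded chain carbon bound to a double-bonded chain carbon gives a 1.3-fold higher number from compound 1 to compound 3 (0.10 log units; within the scatter), so on the core of compound 1 this swap of a five-membered ring for a six-membered ring leaves growth inhibition effectively unchanged. Compound 2, at 7000 nM, carries the same 4-chlorophenyl as compound 3, so that group alone does not bring the lower number. Nothing measured here explains why this exchange changes so little.

On these data alone, it remains open whether a ring carrying an amine or a carboxylic acid, or a plain longer chain, would shift the number at this position. Also open, as far as these compounds go, is how the part in which compound 2 and compound 3 differ behaves when it is varied further.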